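Swapping a fluoro for a methoxy on a chalcone

The source may report more compounds than this note shows. Statements on the series, on what has been measured and on what is new or still open speak of the compounds shown alone.

Compound 1 `COc1cc(C(=O)/C=C/c2c(-c3cccs3)nc3ccccn23)cc(OC)c1OC`: 3650 nM
Compound 2 `COc1cc(C(=O)/C=C/c2c(-c3ccc(F)cc3)nc3ncccn23)cc(OC)c1OC`: 2840 nM

In a functional assay on Malme-3M cells (Homo sapiens) for inhibition, read by sulforhodamine B assay, with a stated time of 48 h (a higher number here means a weaker inhibitor of growth, a lower number a stronger inhibitor of growth), compound 2 gives the lower of the two numbers, yet its gap to compound 1 lies within the scatter, so neither can be called the stronger growth inhibitor. Compound 3 `COc1ccc(-c2nc3ncccn3c2/C=C/C(=O)c2cc(OC)c(OC)c(OC)c2)cc1` is not yet measured. It differs from compound 2 in one place: methoxy in place of fluoro on an aromatic carbon. Within the data shown here, no measured pair shows this change, so any expectation is loose. A modest move toward a lower number is expected, within the step of a 1.9-fold lower number from compound 2 to compound 3 (0.28 log units; within the scatter). For compound 3 the estimate is 1500 nM, with a range from 400 nM to 6000 nM.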

Compound 3, concentration for 50% growth inhibition: 1810 nM
For compound 3 the middle estimate is 1.2-fold (0.08 log units) below the measured one; the measured number falls inside the stated range.
By their numbers in this assay, from the lowest: compounds 3, 2 and 1 (each within the scatter of the next).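

Placing methoxy where compound 2 carries fluoro, para to a large group, gives a 1.6-fold lower number from compound 2 to compound 3 (0.20 log units; within the scatter) and so stays within the scatter: 4-fluorophenyl and 4-methoxyphenyl cannot be told apart here. This first direct reading of the position shows that a group with more heavy atoms and a hydrogen-bond acceptor brings no clear loss of growth inhibition. No other measurement explains this small step.

From the compounds shown here alone, whether an amine or a carboxylic acid here would move the number beyond the scatter remains open. So does the effect of a longer chain, such as ethoxy.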